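The compounds below may be only part of what the source reports. "The series", "measured", "known", "first", "only" and "open" are said of these compounds alone.

Within the data shown here, compound 1 `C=C[C@@H]1OC(c2ccc(Br)cc2)=N[C@H]1SC(C)=O` is the weakest of the three measured members: in an assay on isolated protein for inhibition of matrix metalloproteinase-9 (Homo sapiens) (on this read-out lower numbers stand for stronger inhibition and higher numbers for weaker inhibition), compound 1 gives 88000 nM. Among the measured compounds shown here, compound 2 `C=C[C@@H]1OC(/C=C/c2ccccc2)=N[C@H]1CO` gives 40000 nM, and compound 3 `C=C[C@@H]1OC(/C=C/c2ccc(Br)cc2)=N[C@H]1CO` gives 22000 nM; the only measured step, a 1.8-fold lower number from compound 2 to compound 3 (0.26 log units; within the scatter), is within the scatter. Compound 4 `C=C[C@@H]1OC(c2ccc(Br)cc2)=N[C@H]1Sc1ccccc1` differs from compound 1 by phenyl in place of acetyl on a sulfur. For the measured compounds named here, no measured step touches the substituent on sulfur; the step from compound 2 to compound 3 concerns a bromo on an aromatic carbon and does not bear on this change. No step beyond the scatter is therefore expected in this assay, and the step of a 1.1-fold higher number from compound 1 to compound 4 (0.06 log units; within the scatter) is an estimate without precedent in the series. Compound 4 is expected to give 100000 nM, within 30000 nM to 300000 nM.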

Compound 4, inhibition constant: 94000 nM
The estimate for compound 4 lay 1.1-fold (0.03 log units) above the measured number; measured number inside the range.
By their numbers in this assay, from the lowest: compounds 3 and 2 (each within the scatter of the next); then compounds 1 and 4 (each within the scatter of the next).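

Among these compounds, on the sulfur, replacing acetylsulfanyl with phenylsulfanyl gives a 1.1-fold higher number from compound 1 to compound 4 (0.03 log units; within the scatter) in this assay, the first reading at this position. The assay does not separate the two groups, although the phenyl brings an aromatic ring and more heavy atoms and lacks the hydrogen-bond acceptor of the acetyl. No evidence on hand accounts for this result.

Going by these compounds, whether an amine, a carboxylic acid or a longer alkyl chain on this sulfur would give a step beyond the scatter remains open. Also open, on these data alone, is whether any group at this position brings the number close to the range of stronger inhibitors.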